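Metabolic stability notes: heteroaryl swap on the fused core

This account rests on a few compounds, and the source may have more. Where it says the series, first, only, none or still open, it means among the compounds named here.

Measured so far:
compound 1, `CC(C)COc1cc(NC(=O)C2(NC(=O)c3ccc4c(C5CCCC5)c(-c5ccccn5)n(C)c4c3)CCC2)ccc1/C=C/C(=O)O`, an ADME assay (liver) for metabolic stability, with Liver microsome (Homo sapiens) as the target, using microsomes; on this read-out lower numbers stand for a shorter-lived compound and higher numbers for a longer-lived compound: > 5 h
compound 2, `CCOc1cc(NC(=O)C2(NC(=O)c3ccc4c(C5CCCC5)c(-c5cnn(C)c5)n(C)c4c3)CCC2)ccc1/C=C/C(=O)O`, this assay: 0.733 h

The value for compound 1 is a limit of this assay, not a number. For the measured compounds named here, compound 2 provides the only number in the set. Compound 3, `CCOc1cc(NC(=O)C2(NC(=O)c3ccc4c(C5CCCC5)c(-c5nccs5)n(C)c4c3)CCC2)ccc1/C=C/C(=O)O`, carries 1,3-thiazol-2-yl in place of 1-methyl-1H-pyrazol-4-yl on an aromatic carbon. Going by the values given here, no measured step of this kind is available, so the direction is open; a step no larger than the usual scatter is expected here. Compound 3 is estimated at 0.9 h, with a range from 0.35 h to 2.5 h, the expected step from compound 2 to compound 3 being a 1.2-fold higher number from compound 2 to compound 3 (0.09 log units; within the scatter).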

Compound 3, half-life: 0.6 h
The estimate for compound 3 lay 1.5-fold (0.18 log units) above the measured number; low and high end bracket the measured number.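

In this assay, 1,3-thiazol-2-yl in place of 1-methyl-1H-pyrazol-4-yl on this aromatic carbon gives a 1.2-fold lower number from compound 2 to compound 3 (0.09 log units; within the scatter). For the compounds shown here, this is the first readable step at this position, and it does not separate these two five-membered aromatic rings. Compound 1 differs from compound 3 in more than one place, and its value is a limit, not a number: the limit of > 5 h in this assay, at which 1 of the 3 values shown sits.

As far as these compounds go, whether a phenyl ring or a morpholine at this position would give a step beyond the scatter remains open. Also open, from the compounds shown here alone, is how the aromatic ring and the ether chain of compound 1 each contribute to its value.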